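Changing the Ring Attached to the Carbonyl Carbon

The compounds below may be only part of what the source reports. "The series", "measured", "known", "first", "only" and "open" are said of these compounds alone.

Measured so far in a functional assay on SK-BR-3 cells (Homo sapiens) for antiproliferative activity, read by XTT assay, with a stated time of 72 h; a lower number here means a stronger inhibitor, a higher number a weaker inhibitor:
Compound 1, `COc1ccc(-c2cc3ccccc3nc2C=O)cc1`, gives > 10000 nM; this is a limit of the assay, not a number.
Compound 2, `COc1ccc(-c2cc3ccccc3nc2/C=C/C(=O)c2ccc(N)cc2)cc1`, gives 8560 nM.
Compound 3, `COc1ccc(-c2cc3ccccc3nc2/C=C/C(=O)c2ccsc2)cc1`, gives 660 nM.

Compound 2 has the highest number among the two that were read as numbers; the nearest is compound 3, reached by a 13-fold lower number from compound 2 to compound 3 (1.11 log units; beyond the scatter). Compound 4, `COc1ccc(-c2cc3ccccc3nc2/C=C/C(=O)c2c[nH]c3ccccc23)cc1`, is not yet measured. It differs from compound 2 in one place: 1H-indol-3-yl in place of 4-aminophenyl on a carbonyl carbon. In words, this is 1H-indol-3-yl in place of 4-aminophenyl on a carbonyl carbon.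

Within the data shown here, one measured step bears directly on this site: a 13-fold lower number from compound 2 to compound 3 (1.11 log units; beyond the scatter), a large step that came from changing the group on the carbonyl carbon alone. The other step, an at least 15-fold lower number from compound 1 to compound 3 (1.18 log units; beyond the scatter), concerns the chain that carries the carbonyl and does not touch the ring on the carbonyl carbon, so it speaks only to the shared core being inactive without that chain. The 1H-indol-3-yl group, like 4-aminophenyl, carries one hydrogen-bond donor, but it is larger and bicyclic. A lower number than compound 2 is expected, though not as low as compound 3; the expected step is a 3.4-fold lower number from compound 2 to compound 4 (0.53 log units; beyond the scatter). Compound 4 is therefore estimated at 2500 nM, with a range from 500 nM to 10000 nM.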

Compound 4, half-maximal inhibitory concentration: 3450 nM
Compound 4: the middle estimate sits 1.4-fold (0.14 log units) below what was measured, and the stated range covers the measured number.
By their numbers in this assay, from the lowest: compound 3; then compound 4; then compound 2. At a limit, above all of these: compound 1.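

The ring on the carbonyl carbon now has three readings in this assay, and the new one shows that this site responds in graded steps, not as a simple on-off switch: a 2.5-fold lower number from compound 2 to compound 4 (0.39 log units; beyond the scatter), while a 5.2-fold higher number from compound 3 to compound 4 (0.72 log units; beyond the scatter). 1H-indol-3-yl and 4-aminophenyl each carry 1 hydrogen-bond donor, so that count alone does not fix the number here, and the larger group, with 9 heavy atoms against 7, still gives the lower number of the two, yet thiophen-3-yl remains lower than either. Only compound 1 sits at a limit, so the steps among compound 2, compound 3 and compound 4 all join real numbers: the limit of > 10000 nM in this assay, at which 1 of the 4 values shown sits.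

What lies behind these differences stays open, as the compounds shown cannot separate the effect of the ring's size from that of its hydrogen-bond donor. An unsubstituted phenyl ring or a 1-methylindol-3-yl group, which lacks the hydrogen on the indole nitrogen, would be the natural next points of comparison at this carbonyl carbon.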